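Aryl halogen swap on the inactive ethyl analogue

The compounds below may be only part of what the source reports. "The series", "measured", "known", "first", "only" and "open" are said of these compounds alone.

For the measured compounds named here, in a functional assay on the whole organism (strain Swiss) with Mus musculus as the target, in the maximal electroshock model, with a stated time of 0.25 h, at a dose of 100 mg/kg by the intraperitoneal route (a lower number here means a weaker effect, a higher number a stronger effect of the compound at the dose given), compound 1 `CCC(C(=O)N1CCN(c2cccc(F)c2)CC1)N1C(=O)CCC1=O` gives 0%, the lowest of the two numbers so far. Compound 2 `CC(C(=O)N1CCN(c2cccc(F)c2)CC1)N1C(=O)CCC1=O` gives 75%, and a number 75 percentage points higher from compound 1 to compound 2 (beyond the scatter). Compound 3 `CCC(C(=O)N1CCN(c2cccc(Cl)c2)CC1)N1C(=O)CCC1=O` differs from compound 1 only by chloro in place of fluoro on an aromatic carbon. Going by the values given here, no measured step touches the aromatic ring, so the one step known, at the saturated chain carbon, gives no guide here. With compound 1 at the bottom, the expected result is a small rise at most, a number 10 percentage points higher from compound 1 to compound 3 (within the scatter), and compound 3 is estimated at 10%, within 0% to 45%.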

Compound 3, a percentage reported as activity, at one dose (the size of the read-out at that dose, not a potency): 50%
Compound 3: the middle estimate sits 40 percentage points below what was measured; the whole stated range lies below it.
By their numbers in this assay, from the lowest: compound 1; then compound 3; then compound 2.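

The 3-fluorophenyl to 3-chlorophenyl change alone makes a large difference in this assay, with a number 50 percentage points higher from compound 1 to compound 3 (beyond the scatter). The low read-out of compound 1 therefore does not depend on the saturated chain carbon alone, since the aromatic carbon meta to a large group also strongly affects the result. Nothing available explains why chloro and fluoro differ here.

Open, on these data alone, is whether bromo, methoxy or trifluoromethyl at this aromatic carbon would follow chloro or fluoro. Also open, as far as these compounds go, is whether chloro in place of fluoro has a similar effect on compound 2.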